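This account rests on a few compounds, and the source may have more. Where it says the series, first, only, none or still open, it means among the compounds named here.

Among the measured compounds shown here, compound 3, with the structure `Cc1nc2ccccc2c(=O)n1NCc1nnc(/N=C/c2ccccc2)s1`, is one of three compounds measured in a functional assay on the whole organism (strain albino) with Rattus norvegicus as the target, in the maximal electroshock model, with a stated time of 1 h, at a dose of 30 mg/kg by the intraperitoneal route (on this read-out higher numbers stand for more inhibition at the one dose given (going by the name of the read-out) and lower numbers for less inhibition), and in that assay compound 3 gives 50%. Compound 1, `Cc1nc2ccccc2c(=O)n1NCc1nnc(/N=C/c2ccc(N(C)C)cc2)s1`, shares its core and carries a dimethylamino group on the aromatic ring; in this assay compound 1 gives 50%. Compound 2, `COc1cc(/C=N/c2nnc(CNn3c(C)nc4ccc(Br)cc4c3=O)s2)ccc1O`, carries a bromine on the core and the 4-hydroxy-3-methoxyphenyl group; in this assay compound 2 gives 50%. For the measured compounds named here, the three values sit level with one another, and the one step that can be read between them, no change at the digits printed from compound 1 to compound 3 (within the scatter), shows that trading a dimethylamino group for hydrogen on the aromatic ring moved nothing beyond the scatter.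

Compound 4, `COc1cc(/C=N/c2nnc(CNn3c(C)nc4ccccc4c3=O)s2)ccc1O`, is not yet measured. It differs from compound 3 by 4-hydroxy-3-methoxyphenyl in place of phenyl on a carbon with a double bond to nitrogen. The closest guide is the step from compound 1 to compound 3, which was flat, and the fact that compound 2, which already holds the 4-hydroxy-3-methoxyphenyl group, gives a value level with compound 3. On this basis the expected step of no change at the digits printed from compound 3 to compound 4 (within the scatter) is none beyond the scatter. The estimate for compound 4 in this assay is therefore 50%, expected to fall between 30% and 70%.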

Compound 4, a percentage reported as inhibition, in the whole organism at one dose (the size of the read-out at that dose, not a potency): 50%
For compound 4 middle estimate and measured number coincide at the digits printed; the range from low to high includes it.
By their numbers in this assay, from the lowest: compounds 1, 2, 3 and 4 (each within the scatter of the next).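

In this assay, 4-hydroxy-3-methoxyphenyl in place of phenyl on a carbon with a double bond to nitrogen gives no change at the digits printed from compound 3 to compound 4 (within the scatter), so this place now has a direct reading for a group that brings a hydrogen-bond donor and hydrogen-bond acceptors where phenyl brings none. Set against 4-(dimethylamino)phenyl at the same place, the same group gives no change at the digits printed from compound 1 to compound 4 (within the scatter), which means that all three aromatic groups shown there read alike at this one dose, whether or not they carry a hydrogen-bond donor. Hydrogen in place of bromo on an aromatic carbon of the core gives no change at the digits printed from compound 2 to compound 4 (within the scatter), the first reading of a change on the core itself rather than on the group at the carbon with a double bond to nitrogen.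

The compounds shown leave open whether a carboxylic acid on the phenyl ring, a saturated amine such as piperidine in place of the aromatic group, or a longer chain in place of the methyl on the core would read differently, and a single dose cannot tell whether the four compounds differ in potency. Nothing available here bears on why the values sit level.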